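Amide exchanges in the series and the acetamido step

The compounds below may be only part of what the source reports. "The series", "measured", "known", "first", "only" and "open" are said of these compounds alone.

compound 1 `O=C(O)c1ccc2c(c1)nc(-c1ccc(OCc3cc(C(=O)NCCO)ccc3-c3ccc(Cl)cc3)cc1F)n2C1CCCCC1` gives 26000 nM
compound 2 `CN(C)C(=O)c1ccc(-c2ccc(Cl)cc2)c(COc2ccc(-c3nc4cc(C(=O)O)ccc4n3C3CCCCC3)c(F)c2)c1` gives 26000 nM
compound 3 `O=C(O)c1ccc2c(c1)nc(-c1ccc(OCc3cc(C(=O)N4CCCCC4)ccc3-c3ccc(Cl)cc3)cc1F)n2C1CCCCC1` gives 24000 nM

In a functional assay on Huh-5-2 cells (Homo sapiens), read by MTT assay (on this read-out lower numbers stand for higher toxicity in this test and higher numbers for lower toxicity in this test), compound 3 gives 24000 nM and sits within the scatter of compound 1 and compound 2, so the three values cannot be ranked. Compound 4 `CC(=O)Nc1ccc(-c2ccc(Cl)cc2)c(COc2ccc(-c3nc4cc(C(=O)O)ccc4n3C3CCCCC3)c(F)c2)c1` has acetamido in place of (piperidin-1-yl)carbonyl on an aromatic carbon, para to a 4-chlorophenyl group. The change reads acetamido in place of (piperidin-1-yl)carbonyl on an aromatic carbon and is the only difference between the two structures.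

The closest evidence is the set of steps on the carbonyl carbon: no change at the digits printed from compound 1 to compound 2 (within the scatter) and a 1.1-fold lower number from compound 1 to compound 3 (0.03 log units; within the scatter) and a 1.1-fold lower number from compound 2 to compound 3 (0.03 log units; within the scatter) all stay within the scatter. Among the compounds with values here, these steps exchange only the amino part on that carbonyl, and no measured compound carries acetamido, so the evidence is indirect. No step beyond the scatter is expected in this assay for this change, and no direction is favoured. The estimated step is a 1.1-fold higher number from compound 3 to compound 4 (0.03 log units; within the scatter) in size. For compound 4 the estimated value is 26000 nM with an expected range of 13000 nM to 50000 nM pending measurement.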

Compound 4, half-maximal cytotoxic concentration: 24000 nM
Estimate against measurement, compound 4: 1.1-fold (0.03 log units) above; measured number inside the range.
By their numbers in this assay, from the lowest: compounds 3, 4, 1 and 2 (each within the scatter of the next).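

The earlier steps shown here exchanged only the amino part on a carbonyl; here the group on the aromatic carbon, para to a 4-chlorophenyl group, is attached through nitrogen instead, and this assay gives no change at the digits printed from compound 3 to compound 4 (within the scatter), a 1.1-fold lower number from compound 2 to compound 4 (0.03 log units; within the scatter) and a 1.1-fold lower number from compound 1 to compound 4 (0.03 log units; within the scatter). The read-out at this position therefore stays within the scatter across compound 1, compound 2, compound 3 and compound 4, including the exchange in which the six-membered non-aromatic ring of (piperidin-1-yl)carbonyl leaves and the amide hydrogen of acetamido enters. No measurement at hand explains this flat picture.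

On these data alone, a free amine or a methylsulfonyl group on this carbon remains open, as does a longer acylamino chain such as hexanoylamino. As far as these compounds go, whether any group here can move the number beyond the scatter also remains open.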